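Compound 2 to compound 4: fluoro in place of methyl

The source may hold more compounds than are shown below. What is called first, only, known or untested is meant among the compounds shown, and "the series" means these compounds.

In an ADME assay on BHK-21 cells (Mesocricetus auratus) for cytotoxicity, read by MTT assay, with a stated time of 72 h (on this read-out lower numbers stand for higher toxicity in this test and higher numbers for lower toxicity in this test), compound 1 `NS(=O)(=O)c1ccc(N2N=C(c3ccc(Oc4ccccc4)cc3)CC2c2ccccc2)cc1` gives 11000 nM, compound 2 `Cc1cccc(C2CC(c3ccc(Oc4ccccc4)cc3)=NN2c2ccc(S(N)(=O)=O)cc2)c1` gives 8000 nM and compound 3 `NS(=O)(=O)c1ccc(N2N=C(c3ccc(OCc4ccccc4)cc3)CC2c2ccc(Cl)cc2)cc1` gives 15000 nM. Compound 2 has the lowest number of the three, yet it lies within the scatter of both compound 1 and compound 3, so these values do not separate the compounds.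

Compound 4 `NS(=O)(=O)c1ccc(N2N=C(c3ccc(Oc4ccccc4)cc3)CC2c2cccc(F)c2)cc1` has fluoro in place of methyl on an aromatic carbon, meta to a large group, that is, 3-methylphenyl to 3-fluorophenyl (fluoro in place of methyl on an aromatic carbon). Among the compounds with values here, no measured compound carries fluoro, so the evidence is indirect. Within the data shown here, the one measured step that bears on this change adds the same methyl, and compound 2 differs from compound 1 by a 1.4-fold lower number from compound 1 to compound 2 (0.14 log units; within the scatter), which is within the scatter. No step beyond the scatter is therefore expected in this assay. The estimated step is a 1.3-fold higher number from compound 2 to compound 4 (0.10 log units; within the scatter), and it is expected to stay within the scatter. Compound 4 is estimated at 10000 nM, with an expected range of 5500 nM to 19000 nM.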

Compound 4, half-maximal cytotoxic concentration: 10000 nM
Compound 4: middle estimate and measured number agree at the digits printed; low and high end bracket the measured number.
By their numbers in this assay, from the lowest: compounds 2, 4, 1 and 3 (each within the scatter of the next).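

In this assay, fluoro now joins hydrogen and methyl on this aromatic carbon: 3-methylphenyl to 3-fluorophenyl gives a 1.3-fold higher number from compound 2 to compound 4 (0.10 log units; within the scatter) in this series, and fluoro in place of hydrogen gives a 1.1-fold lower number from compound 1 to compound 4 (0.04 log units; within the scatter) on the same carbon. Together with a 1.4-fold lower number from compound 1 to compound 2 (0.14 log units; within the scatter) as the earlier step, this places all three substituents within the scatter of one another. Across compounds 1, 2 and 4, this single place therefore shows no separation in this read-out, for a swap of methyl for fluoro or for either group in place of hydrogen.

As far as these compounds go, whether an amine or a carboxylic acid in place of the fluoro would move the number beyond the scatter remains open. No measured property of these groups is available to account for the numbers.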